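Methoxy for chloro on the pyridine-bearing phenylpropanoic acids

The source may report more compounds than this note shows. Statements on the series, on what has been measured and on what is new or still open speak of the compounds shown alone.

Measured compounds in an in vitro functional assay on 1321-N1 cells for agonist activity at Free fatty acid receptor 1 (Homo sapiens), read by fluorescence, spectrophotometry and calcium flux; on this read-out higher numbers stand for an effect only at larger amounts of compound and lower numbers for an effect already at smaller amounts:
compound 1 `O=C(O)CCc1ccc(C#Cc2ccnc(-c3ccccc3)c2)cc1` gives 186 nM
compound 2 `O=C(O)CCc1ccc(C#Cc2ccnc(F)c2)cc1` gives 513 nM
compound 3 `O=C(O)CCc1ccc(C#Cc2ccnc(Cl)c2)cc1` gives 295 nM

Compound 3 stands second highest of the three numbers in this assay. Its nearest neighbour is compound 1: a 1.6-fold higher number from compound 1 to compound 3 (0.20 log units; within the scatter). Its furthest is compound 2: a 1.7-fold lower number from compound 2 to compound 3 (0.24 log units; within the scatter). Among the compounds with values here, only one step in the set goes beyond the scatter, a 2.8-fold higher number from compound 1 to compound 2 (0.44 log units; beyond the scatter).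

Compound 4 `COc1cc(C#Cc2ccc(CCC(=O)O)cc2)ccn1` differs from compound 3 in one place: methoxy in place of chloro on an aromatic carbon. Within the data shown here, none of the measured steps carries a methoxy group, so no step bears directly on it. What bears indirectly is the pair of steps at this aromatic carbon: the exchange of chloro for fluoro and of chloro for phenyl each stayed within the scatter, so three rather different groups at this position give numbers close to one another. A methoxy group is therefore expected to leave the number near that of compound 3, with no step beyond the scatter as the most likely outcome, in either direction.

For compound 4 the estimate in this assay is 350 nM, with a range of 150 nM to 800 nM, which means an expected step of a 1.2-fold higher number from compound 3 to compound 4 (0.07 log units; within the scatter).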

Compound 4, half-maximal effective concentration: 525 nM
The estimate for compound 4 lay 1.5-fold (0.18 log units) below the measured number; measured number inside the range.
By their numbers in this assay, from the lowest: compounds 1, 3, 2 and 4 (each within the scatter of the next, the first and the last beyond it).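

In this assay, methoxy on this aromatic carbon next to the ring nitrogen reads within the scatter of both halogens, with a 1.8-fold higher number from compound 3 to compound 4 (0.25 log units; within the scatter) and a 1.0-fold higher number from compound 2 to compound 4 (0.01 log units; within the scatter), so an oxygen-linked group adds no separation from chloro or fluoro. The comparison with phenyl is the informative one: a 2.8-fold higher number from compound 1 to compound 4 (0.45 log units; beyond the scatter), a modest step beyond the scatter that joins a 2.8-fold higher number from compound 1 to compound 2 (0.44 log units; beyond the scatter) and shows that phenyl separates from two small groups at this position, with compound 3 as the exception. Compound 3 lies within the scatter of all three others. No measurement at hand accounts for this separation.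

The compounds shown leave open whether the reading of compound 1 at 186 nM belongs to phenyl alone or extends to other rings at this carbon, such as a pyridine or a thiophene. On these data alone, how an amine, a nitrile, a trifluoromethyl or a longer ether such as ethoxy would read here also remains open, as does whether any of them would move beyond the scatter of compound 3.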